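A few compounds are considered here, and "the series" means these few. Any claim that something is new, unique, unknown or untested is made for them only; others in the source may bear on it.

Measured so far:
compound 1 `O=C(Nc1ccc(C(F)(F)F)cc1)NC1CCN(C(=O)C2CCOC2)CC1` — 9.6 ug/mL
compound 2 `O=C(Nc1ccc(OC(F)(F)F)c(F)c1)NC1CCN(C(=O)C2CC2)CC1` — 19 ug/mL
compound 3 `O=C(Nc1ccc(OC(F)(F)F)cc1)NC1CCN(C(=O)C2CCOC2)CC1` — 29 ug/mL

In a physicochemical assay for solubility, read by mass spectrometry, in phosphate buffer, with a stated time of 24 h, at pH 7.4 (on this read-out lower numbers stand for lower solubility and higher numbers for higher solubility), compound 1 gives 9.6 ug/mL, the lowest of the three numbers. Compound 2 lies within the scatter of compound 1, so the two cannot be told apart; compound 3 stands further off, and the only step that is shown, a 3.0-fold higher number from compound 1 to compound 3 (0.48 log units; beyond the scatter), is a modest gain that comes from a change on the aromatic ring, not on the acyl side of the shared core.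

Compound 4 `O=C(Nc1ccc(C(F)(F)F)cc1)NC1CCN(C(=O)c2cc[nH]c2)CC1` is the next compound to be measured in this assay. It differs from compound 1 in one place: 1H-pyrrol-3-yl in place of oxolan-3-yl on a carbonyl carbon. None of the measured compounds differs from another by this kind of change, so no step shown here bears directly on it. Compound 2 and compound 3 differ in the acyl group as well, but they also differ on the aromatic ring, so their two values cannot be read as a clean step for the acyl group alone.

For the measured compounds named here, with no step to lean on, the expectation for compound 4 is a number close to that of compound 1, with a change of roughly a 1.4-fold lower number from compound 1 to compound 4 (0.14 log units; within the scatter), and a wide range. Compound 4 is therefore estimated at 7 ug/mL, between 2 ug/mL and 25 ug/mL.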

Compound 4, solubility: 1.8 ug/mL
Estimate against measurement, compound 4: 3.9-fold (0.59 log units) above; the whole stated range lies above it.
By their numbers in this assay, from the lowest: compound 4; then compounds 1, 2 and 3 (each within the scatter of the next, the first and the last beyond it).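

The carbonyl carbon on the acyl side of the shared core now has a clean step of its own: in this assay, 1H-pyrrol-3-yl in place of oxolan-3-yl gives a clear drop (a 5.3-fold lower number from compound 1 to compound 4 (0.73 log units; beyond the scatter)). For the compounds shown here, until now the only clean step lay on the aromatic ring and pointed upward (a 3.0-fold higher number from compound 1 to compound 3 (0.48 log units; beyond the scatter)), so this result shows that the acyl side can also move the number, and in the opposite direction. Both groups are five-membered rings with one hetero atom and the same count of heavy atoms, so the swap leaves size by that count unchanged while replacing a non-aromatic ring bearing oxygen with an aromatic ring bearing a nitrogen with its hydrogen-bond donor, but no measurement here tells which of these differences matters.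

As far as these compounds go, it remains open whether the same swap would lower the number to a similar extent on the trifluoromethoxy compound 3. Nor do the compounds shown tell how an open-chain amine, a carboxylic acid or a longer ether chain on this carbonyl carbon would read.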